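The source may report more compounds than this note shows. Statements on the series, on what has been measured and on what is new or still open speak of the compounds shown alone.

Two compounds of this series share one core and carry a substituted methyl group on it. Compound 1, `CCNC(=O)NCC1(C(=O)Nc2ccc(-c3ccccc3S(N)(=O)=O)cn2)CC(c2ccc(Cl)c(N)c2)=NO1`, in an assay on isolated protein for inhibition of serine protease 1 (Homo sapiens) (a lower number here means a stronger inhibitor, a higher number a weaker inhibitor), gives > 4200 nM, which is a limit of the measurement rather than a number. Compound 2, `COc1ccc(C2=NOC(CNS(C)(=O)=O)(C(=O)Nc3ccc(-c4ccccc4S(N)(=O)=O)cn3)C2)cc1`, in this assay gives > 4200 nM, again a limit rather than a number. So both values sit at the limit of > 4200 nM in this assay, at which 2 of the 2 values shown sit, and nothing separates the two compounds within what has been measured.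

Compound 3, `Nc1cc(C2=NOC(CNS(=O)(=O)c3ccsc3)(C(=O)Nc3ccc(-c4ccccc4S(N)(=O)=O)cn3)C2)ccc1Cl`, differs from compound 1 in one place: (thiophen-3-yl)sulfonyl in place of ethylcarbamoyl on an amine nitrogen. Among the compounds with values here, no pair of measured compounds shows what a change of this kind does here, so there is no measured step to lean on. The expectation for compound 3 is that the step from compound 1 is a step that the limit leaves unreadable from compound 1 to compound 3, with no movement beyond the usual scatter. The estimate for compound 3 in this assay is 7000 nM, between 2500 nM and 30000 nM.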

Compound 3, inhibition constant: > 8000 nM
Compound 3: no number, only a limit; the forecaster's own chance of this, stated with the estimate: 70%; middle value at least 1.1-fold (0.05 log units) away from the limit.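

Compound 1 and compound 3 both give only limits, not numbers, in this assay, so no step can be read between them. The compounds shown leave open how strongly each one actually inhibits the protease, and whether exchanging the two groups changes that at all.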